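The source may hold more compounds than are shown below. What is called first, only, known or untested is meant among the compounds shown, and "the series" means these compounds.

Working notes on the series. In a functional assay on SW1573 cells (Homo sapiens) for antiproliferative activity, read by sulforhodamine B assay, with a stated time of 48 h (a lower number here means a stronger inhibitor of growth, a higher number a weaker inhibitor of growth), compound 1 (`COC(=O)C#CC(O/C=C/C(=O)OC)C(C)c1ccccc1`) gives 1200 nM and compound 2 (`COC(=O)C#CC(CC(C)C)O/C=C/C(=O)OC`) gives 380 nM. Compound 2 therefore holds the lower of the two numbers, a gap beyond the scatter. Compound 3 (`CCC(C)C(C#CC(=O)OC)O/C=C/C(=O)OC`) has sec-butyl in place of isobutyl on a saturated chain carbon bound to an oxygen on an unsaturated carbon and a triple-bonded carbon. Within the data shown here, no measured pair isolates this change, so the only weak guide is compound 1 at 1200 nM. The expected step, a 1.6-fold higher number from compound 2 to compound 3 (0.20 log units; within the scatter), is small, toward weaker growth inhibition in this assay, and not clearly beyond the scatter. For compound 3 the estimated value is 600 nM, within an expected range of 250 nM to 1400 nM.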

Compound 3, concentration for 50% growth inhibition: 910 nM
For compound 3 the middle estimate is 1.5-fold (0.18 log units) below the measured one, and the stated range covers the measured number.
By their numbers in this assay, from the lowest: compound 2; then compounds 3 and 1 (each within the scatter of the next).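

In this assay there is a 2.4-fold higher number from compound 2 to compound 3 (0.38 log units; beyond the scatter) with sec-butyl in place of isobutyl, so at this position the arrangement of the chain alone moves the number, with the atoms unchanged. Ethyl in place of phenyl gives a 1.3-fold lower number from compound 1 to compound 3 (0.12 log units; within the scatter) and stays within the scatter, so the two branched side chains cannot be separated here. Nothing available explains either step.

Open, going by these compounds, is whether a longer chain, a cyclohexyl group or an amine on this carbon would hold or lower the number. Also open, on these data alone, is whether the isobutyl preference over sec-butyl extends to other cell lines.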